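A few compounds are considered here, and "the series" means these few. Any claim that something is new, unique, unknown or untested is made for them only; others in the source may bear on it.

Compound 1 `Cc1n[nH]c2c1[C@@H](c1ccc(OCc3ccc(Cl)cc3)cc1)S[C@@H](C)C(=O)N2`: "not determined" (no result reported)
Compound 2 `Cc1n[nH]c2c1[C@@H](c1ccc(OCc3ccccc3F)cc1)S[C@@H](C)C(=O)N2`: > 200000 nM

In an ADME assay on L929 cells (Mus musculus) for cytotoxicity, read by microscopy, with a stated time of 96 h (a lower number here means that less compound is tolerated, a higher number that more compound is tolerated), compound 1 has no reported result: "not determined" (no result reported). Compound 2 gives > 200000 nM, which is a limit of the assay and not a number. Compound 3 `Cc1ccccc1COc1ccc([C@H]2S[C@@H](C)C(=O)Nc3[nH]nc(C)c32)cc1` carries 2-methylphenyl in place of the 4-chlorophenyl of compound 1, on a saturated chain carbon bound to an oxygen on an aromatic ring: 2-methylphenyl in place of 4-chlorophenyl on a saturated chain carbon bound to an oxygen on an aromatic ring. Among the measured compounds shown here, no measured step bears on this change, so no step beyond the scatter is expected in this assay. For compound 3 the estimate is 200000 nM, with an expected range of 70000 nM to 300000 nM.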

Compound 3, concentration lethal to 50% of the cells: 111000 nM
Beside the measured number, compound 3's estimate is 1.8-fold (0.26 log units) above it; low and high end bracket the measured number.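

Among the compounds shown here, compound 3, with 2-methylphenyl on a saturated chain carbon bound to an oxygen on an aromatic ring, gives the first value in this assay that is a number and not a limit. Methyl in place of fluoro on an aromatic carbon gives an at least 1.8-fold lower number from compound 2 to compound 3 (0.25 log units; that floor lies within the scatter), so no change beyond the usual scatter can be claimed. The value of compound 2 is a limit, and the step is only a floor for that reason: the limit of > 200000 nM in this assay, at which 1 of the 3 values shown sits.

The step between compound 1 and compound 3 cannot be read, as compound 1 has no result. Also open, from the compounds shown here alone, is how this assay would read with an amine or a carboxylic acid in place of the 2-methylphenyl.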